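Swapping the Thiophene Ring for a Dimethylaminophenyl Group

This account rests on a few compounds, and the source may have more. Where it says the series, first, only, none or still open, it means among the compounds named here.

Compound 1 `Cc1ccsc1/C=C(/SCc1ccc(Cl)cc1)C(=O)c1ccc(Cl)cc1` carries the shared core of this small series. In a functional assay on DU-145 cells (Homo sapiens) for inhibition, read by trypan blue exclusion, with a stated time of 96 h (on this read-out lower numbers stand for stronger inhibition of growth and higher numbers for weaker inhibition of growth), compound 1 gives 50000 nM. Compound 2 `Cc1ccsc1/C=C(/SCc1ccc(Cl)c(Cl)c1)C(=O)c1ccc(Cl)cc1` gives 50000 nM, and compound 3 `Cc1ccsc1/C=C(/SCc1ccccc1F)C(=O)c1ccc(Cl)cc1` gives 50000 nM, so compound 1 stands level with both: the steps of no change at the digits printed from compound 1 to compound 2 (within the scatter) and no change at the digits printed from compound 1 to compound 3 (within the scatter) lie within the scatter. Compound 4 `CN(C)c1ccc(/C=C(/SCc2ccc(Cl)cc2)C(=O)c2ccc(Cl)cc2)cc1` differs from compound 1 by 4-(dimethylamino)phenyl in place of 3-methylthiophen-2-yl on a double-bonded chain carbon bound to a double-bonded chain carbon. Every measured step alters the group on the saturated chain carbon bound to a sulfur; none touches the double-bonded chain carbon, so they give no guide to the direction of this change and only show three compounds sitting at the same number. The step that this estimate means is therefore expected to be a 1.3-fold lower number from compound 1 to compound 4 (0.10 log units; within the scatter). Compound 4 is expected to give 40000 nM, within a range from 5000 nM to 50000 nM.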

Compound 4, concentration for 50% growth inhibition: > 100000 nM
Compound 4 was reported as a limit; the forecaster's own chance of this, stated with the estimate: 50%; at least 2.5-fold (0.39 log units) between middle value and limit.
By their numbers in this assay, from the lowest: compounds 1, 2 and 3 (each within the scatter of the next). At a limit, above all of these: compound 4.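

Placing 4-(dimethylamino)phenyl in place of 3-methylthiophen-2-yl on the double-bonded chain carbon gives an at least 2.0-fold higher number from compound 1 to compound 4 (0.30 log units; that floor lies within the scatter) in this assay. Compound 4 gives > 100000 nM, which is a limit and not a number. This is the only look at that carbon, and the true size of the step stays unknown, with a single value setting its floor: the limit of > 100000 nM in this assay, at which 1 of the 4 values shown sits.

From the compounds shown here alone, whether a plain phenyl group or a 4-aminophenyl group at this place would give a lower number remains open. The compounds shown also cannot separate the change of ring from the dimethylamino group itself.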